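Amide aryl variation on the shared core: biphenyl replaces nitrophenyl

This account rests on a few compounds, and the source may have more. Where it says the series, first, only, none or still open, it means among the compounds named here.

The series varies the aryl group on the carbonyl carbon of the amide carried by the shared core, with activity read in a functional assay on HepG2 cells (Homo sapiens) for antiproliferative activity, read by CCK-8 assay, with a stated time of 72 h; on this read-out higher numbers stand for weaker inhibition and lower numbers for stronger inhibition. Compound 1 `Cc1cccc(C(=O)Nc2cccc(-c3oc4cc(-c5ccc(F)cc5)ccc4c(=O)c3O)c2)c1` gives 13500 nM in this assay. Among the compounds with values here, compound 2 `O=C(Nc1cccc(-c2oc3cc(-c4ccc(F)cc4)ccc3c(=O)c2O)c1)c1ccc([N+](=O)[O-])cc1` gives 1860 nM in this assay, and compound 2 holds the lowest of the two numbers measured so far, with compound 1 as its only neighbour, the gap between them being beyond the scatter. Within the data shown here, the single measured step, a 7.3-fold lower number from compound 1 to compound 2 (0.86 log units; beyond the scatter), is the only information on how the amide aryl group affects this read-out.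

Compound 3 `O=C(Nc1cccc(-c2oc3cc(-c4ccc(F)cc4)ccc3c(=O)c2O)c1)c1ccc(-c2ccccc2)cc1` differs from compound 2 by phenyl in place of nitro on an aromatic carbon. Among the measured compounds shown here, no measured step covers this change: the one step known exchanges two different groups at the amide and does not separate the part played by the nitro group from the rest of that exchange. A direction cannot be read from the data, so the expectation is a small step, not clearly beyond the scatter, with a wide range. Compound 3 is expected to give 3200 nM in this assay, between 800 nM and 13000 nM. This estimate corresponds to an expected step of a 1.7-fold higher number from compound 2 to compound 3 (0.24 log units; within the scatter).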

Compound 3, half-maximal inhibitory concentration: 88500 nM
Compound 3: middle estimate off by 28-fold (1.44 log units), on the low side; measured number above the stated range.
By their numbers in this assay, from the lowest: compound 2; then compound 1; then compound 3.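

In this assay, the aryl group on the amide carbonyl carbon tolerates far less than the first pair suggested: phenyl in place of nitro gives a 48-fold higher number from compound 2 to compound 3 (1.68 log units; beyond the scatter), and 4-phenylphenyl in place of 3-methylphenyl gives a 6.6-fold higher number from compound 1 to compound 3 (0.82 log units; beyond the scatter). The order is now compound 2, then compound 1, then compound 3, so 4-nitrophenyl and 4-phenylphenyl stand at opposite ends with 3-methylphenyl in the middle, and the identity of the group on that aromatic carbon matters, not merely the presence of a group there. No measurement on these compounds accounts for the drop seen with the added phenyl ring.

With only nitro and phenyl compared on that aromatic carbon, the series cannot separate the loss of nitro from the entry of a second aromatic ring. An amine, a carboxylic acid or a methoxy group on the same carbon would show whether the low number of compound 2 is particular to nitro, and a pyridine ring in place of the added phenyl would test the size of the group with its ring kept.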